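Swapping Chloro for Methoxy on a Shared Core

The compounds below may be only part of what the source reports. "The series", "measured", "known", "first", "only" and "open" are said of these compounds alone.

Of the compounds shown here, two have so far been tested in a functional assay on MCF7 cells (Homo sapiens) for antiproliferative activity, read by MTT assay, with a stated time of 48 h; a higher number here means a weaker inhibitor, a lower number a stronger inhibitor. Compound 1, `O=C(/C=C/c1ccccn1)c1nc2ccccc2s1`, and compound 2, `O=C(/C=C/c1cccc(Cl)c1)c1nc2ccccc2s1`, share the same core and differ only in the aromatic ring attached to the double bond. In this assay compound 1 gives > 100000 nM, which is a limit of the assay and not a number. Compound 2 in this assay likewise gives > 100000 nM, again a limit rather than a number. Compound 2 therefore stands at the edge of what this assay can report, as does compound 1: the limit of > 100000 nM in this assay, at which 2 of the 2 values shown sit. Among the measured compounds shown here, because both values are limits, no step between measured compounds can be computed.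

Compound 3, `COc1cccc(/C=C/C(=O)c2nc3ccccc3s2)c1`, differs from compound 2 in one place: methoxy in place of chloro on an aromatic carbon. With only limits in hand, the expectation is that this change makes no difference beyond the scatter, and the estimated step is a number no higher from compound 2 to compound 3 (the limit leaves the size open). Compound 3 is thus expected to give about 100000 nM in this assay, with a range from 30000 nM to 300000 nM, most likely reported again as a limit.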

Compound 3, half-maximal inhibitory concentration: > 100000 nM
Compound 3: a limit, no number; the forecaster's own chance of this, stated with the estimate: 80%; the middle value lies on the limit itself.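

In this assay compound 3 gives > 100000 nM, again a limit of the assay and not a number. Compound 2 also stands at a limit, and no step can be read from compound 2 to compound 3. The compounds shown leave open how any change to the aromatic ring on the shared core affects potency, as every value sits at one edge: the limit of > 100000 nM in this assay, at which 3 of the 3 values shown sit.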